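Methoxy to hydroxy on the aromatic ring of compound 3

The source may report more compounds than this note shows. Statements on the series, on what has been measured and on what is new or still open speak of the compounds shown alone.

Compound 1 `COc1ccc(/C=C/c2cc(C)no2)cc1OC` gives 44700 nM
Compound 2 `Cc1cc(/C=C/c2ccc(O)c(O)c2)on1` gives 11600 nM
Compound 3 `COc1ccc(/C=C/c2cc(C)no2)cc1` gives 70200 nM

All three numbers come from an ADME assay on MDCK cells (Canis lupus familiaris) for cytotoxicity, read by MTT assay, with a stated time of 72 h; a higher number here means a weaker inhibitor, a lower number a stronger inhibitor. Compound 3 sits at the high end of this small set together with compound 1, and the measured step between them, a 1.6-fold higher number from compound 1 to compound 3 (0.20 log units; within the scatter), stays within the scatter. Compound 2 lies clearly lower than both.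

Compound 4 `Cc1cc(/C=C/c2ccc(O)cc2)on1` is reached from compound 3 by one change: hydrogen in place of methyl on an oxygen on an aromatic ring. In words, this is hydrogen in place of methyl on an oxygen on an aromatic ring, or methoxy to hydroxy.

Among the compounds with values here, no measured step makes exactly this change. Within the data shown here, the one measured step removes a methoxy group from an aromatic carbon instead, and it gives little guidance beyond showing that such an edit can leave the number within the scatter. The closer comparison is a pair of compounds that differ by methoxy to hydroxy in two places. Compound 1 gives 44700 nM, whereas compound 2 gives 11600 nM. With only one such place changed here, a smaller move toward a lower number is expected in this assay, near the edge of the scatter. The estimated move is a 2.0-fold lower number from compound 3 to compound 4 (0.30 log units; within the scatter). For compound 4 the expected value is 35000 nM, with an estimated range from 14000 nM to 75000 nM.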

Compound 4, half-maximal inhibitory concentration: 58300 nM
Estimate against measurement, compound 4: 1.7-fold (0.22 log units) below, within the range that was stated.
By their numbers in this assay, from the lowest: compound 2; then compounds 1, 4 and 3 (each within the scatter of the next).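

In this assay the change at this oxygen, taken alone, moves little: methoxy to hydroxy gives a 1.2-fold lower number from compound 3 to compound 4 (0.08 log units; within the scatter) and so, for this pair, a free hydroxy in this place does not by itself separate the two compounds. The larger difference lies elsewhere, since the hydroxy removal from an aromatic carbon gives a 5.0-fold higher number from compound 2 to compound 4 (0.70 log units; beyond the scatter) and is the only single change among the compounds shown that reaches beyond the scatter, whereas the methoxy removal from an aromatic carbon, a 1.6-fold higher number from compound 1 to compound 3 (0.20 log units; within the scatter), does not. Nothing given here accounts for either result.

As far as these compounds go, what stays open is whether that larger step depends on the hydroxy at the oxygen of compound 4 or would also appear with a methoxy there, which these compounds cannot settle. Equally open, from the compounds shown here alone, is how an amine, a carboxylic acid or a longer chain such as ethoxy would read on the same oxygen or aromatic carbon. The compounds shown carry only hydrogen, hydroxy and methoxy in these places.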